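Replacing Trifluoromethyl on the Shared Core

This account rests on a few compounds, and the source may have more. Where it says the series, first, only, none or still open, it means among the compounds named here.

In an ADME assay on L6 cells (Rattus norvegicus) for cytotoxicity, read by resazurin assay (a lower number here means a stronger inhibitor, a higher number a weaker inhibitor), compound 1 `N=C(N)c1ccc(Nc2nc3ccccc3[nH]2)cc1` gives 123000 nM. Within the data shown here, compound 2 `N=C(N)c1ccc(Nc2nc3cc(C(F)(F)F)ccc3[nH]2)cc1` gives 41400 nM, the lower of the two numbers measured so far. Compound 3 `N=C(N)c1ccc(Nc2nc3cc(C(=N)N)ccc3[nH]2)cc1` has not yet been measured. It keeps the shared core but alters compound 2 on an aromatic carbon: a group of 3 heavy atoms (1 carbon, 2 nitrogen; no ring) in place of a group of 4 heavy atoms (1 carbon, 3 fluorine; no ring), on an aromatic carbon.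

Among the measured compounds shown here, only one measured step bears on this change: a 3.0-fold lower number from compound 1 to compound 2 (0.47 log units; beyond the scatter). That modest step, beyond the scatter, came from adding trifluoromethyl in place of hydrogen. Compound 3 loses trifluoromethyl but gains a different group rather than hydrogen, so this single step is only a rough guide. A modest move back towards the higher number seems the most reasonable expectation, with considerable uncertainty.

The expected change is a 2.2-fold higher number from compound 2 to compound 3 (0.34 log units; beyond the scatter). For compound 3, the estimated value is 90000 nM, with an expected range of 25000 nM to 250000 nM.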

Compound 3, half-maximal inhibitory concentration: 105000 nM
Compound 3: middle estimate off by 1.2-fold (0.07 log units), on the low side; low and high end bracket the measured number.
By their numbers in this assay, from the lowest: compound 2; then compounds 3 and 1 (each within the scatter of the next).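

In this assay, this aromatic carbon does not respond to every group alike: exchanging trifluoromethyl for the new group gives a 2.5-fold higher number from compound 2 to compound 3 (0.40 log units; beyond the scatter) and so undoes the earlier gain, while the same group in place of hydrogen gives a 1.2-fold lower number from compound 1 to compound 3 (0.07 log units; within the scatter) and so leaves the number within the scatter. At this position, then, the new group cannot be told apart from hydrogen, and of the three groups shown only trifluoromethyl stands apart from the other two, beyond the scatter. Nothing available here accounts for that difference between the two groups.

From the compounds shown here alone, whether a chlorine atom, an amine or a carboxylic acid on this same carbon would fall nearer to compound 2 or to compound 1 remains open. The compounds shown also say nothing about how the other aromatic carbons of the shared core respond to these groups.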